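Methyl on a Ring Nitrogen and Tolerance in Leukemia Cells

The source may report more compounds than this note shows. Statements on the series, on what has been measured and on what is new or still open speak of the compounds shown alone.

Compound 1 `CC(=O)Nc1cccc2c1nc(-c1c(F)cccc1F)n2Cc1c(F)cccc1F` and compound 2 `CC(=O)N(C)c1cccc2c1nc(-c1c(F)cccc1F)n2Cc1c(F)cccc1F` share a core and differ by methyl in place of hydrogen on an amide-type nitrogen. In a toxicity assay on CCRF-CEM cells (Homo sapiens) for cytotoxicity (a higher number here means that more compound is tolerated, a lower number that less compound is tolerated), compound 1 gives 39.3 uM. For compound 2 the assay reports only a limit, > 100 uM. That gives an at least 2.5-fold higher number from compound 1 to compound 2 (0.40 log units; beyond the scatter), a step that reaches (the limit of > 100 uM in this assay, at which 1 of the 3 values shown sits). Compound 3 `CNc1cccc2c1nc(-c1c(F)cccc1F)n2Cc1c(F)cccc1F` differs from compound 1 by methyl in place of acetyl on a nitrogen on an aromatic ring; in this assay compound 3 gives 27.2 uM, a 1.4-fold lower number from compound 1 to compound 3 (0.16 log units; within the scatter). Compound 4 `CN(C)c1cccc2c1nc(-c1c(F)cccc1F)n2Cc1c(F)cccc1F` is not yet measured; it differs from compound 3 by methyl in place of hydrogen on a nitrogen on an aromatic ring. This is the same kind of change as from compound 1 to compound 2, though the place differs: there the nitrogen's other neighbours are aromatic carbon, carbonyl carbon, here aromatic carbon, saturated chain carbon. Resting on an at least 2.5-fold higher number from compound 1 to compound 2 (0.40 log units; beyond the scatter), compound 4 is expected to show a 2.2-fold higher number from compound 3 to compound 4 (0.34 log units; beyond the scatter), with 60 uM estimated, between 25 uM and 150 uM.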

Compound 4, half-maximal toxic concentration: > 100 uM
Compound 4 was reported as a limit; the forecaster's own chance of this, stated with the estimate: 30%; at least 1.6-fold (0.22 log units) between middle value and limit.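

Methyl in place of hydrogen on the nitrogen moves the number in the same direction on both cores in this assay, so in these two cases the change carries over in direction: the same change on two cores in this assay, an at least 2.5-fold higher number (0.40 log units; beyond the scatter) from compound 1 to compound 2 and an at least 3.6-fold higher number (0.56 log units; beyond the scatter) from compound 3 to compound 4; the limit leaves it open whether they differ. The newest step is an at least 3.6-fold higher number from compound 3 to compound 4 (0.56 log units; beyond the scatter), and the wider change of dimethylamino in place of acetamido gives an at least 2.5-fold higher number from compound 1 to compound 4 (0.40 log units; beyond the scatter), while the step between the two compounds that both stop at a limit, compound 2 and compound 4, cannot be read. What this does not show is the true size of either methyl step, or whether the two sizes match: the limit of > 100 uM in this assay, at which 2 of the 4 values shown sit.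

From the compounds shown here alone, whether an ethyl group or a longer chain on this nitrogen would move the number the same way remains open. So does whether the change would carry over to a third core.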